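A few compounds are considered here, and "the series" means these few. Any claim that something is new, unique, unknown or untested is made for them only; others in the source may bear on it.

Measured so far in a functional assay on MCF7 cells (Homo sapiens) for inhibition, with a stated time of 72 h; a higher number here means a weaker inhibitor, a lower number a stronger inhibitor:
Compound 1, `NC1CCC(Nc2nc(NCc3ccc(-c4ccsc4)cc3)c3ncn(C4CCCC4)c3n2)CC1`, gives 145 nM.
Compound 2, `NC1CCC(Nc2nc(NCc3ccc(-c4ccsc4)nc3)c3ncn(C4CCCC4)c3n2)CC1`, gives 100 nM.
Compound 3, `NC1CCC(Nc2nc(NCc3ccc(-c4ccccc4O)cc3)c3ncn(C4CCCC4)c3n2)CC1`, gives 2910 nM.

All three share one core, and a fourth member, compound 4, `NC1CCC(Nc2nc(NCc3ccc(-c4ccccc4O)nc3)c3ncn(C4CCCC4)c3n2)CC1`, has not yet been run in this assay. Compound 2 differs from compound 1 by 6-(thiophen-3-yl)pyridin-3-yl in place of 4-(thiophen-3-yl)phenyl on a saturated chain carbon bound to a nitrogen on an aromatic ring, and that step gave a 1.5-fold lower number from compound 1 to compound 2 (0.16 log units; within the scatter). Compound 3 differs from compound 1 by 2-hydroxyphenyl in place of thiophen-3-yl on an aromatic carbon, and here the step was a 20-fold higher number from compound 1 to compound 3 (1.30 log units; beyond the scatter). Compound 4 differs from compound 2 by the same kind of change, (2-hydroxyphenyl in place of thiophen-3-yl on an aromatic carbon). The two places are not the same: in compound 3 the change sits on a six-membered aromatic ring of carbon only, whereas in compound 4 it sits on a six-membered aromatic ring with 1 nitrogen, next to the ring nitrogen. Within the data shown here, the expected step in this assay is a 20-fold higher number from compound 2 to compound 4 (1.30 log units; beyond the scatter) because a 20-fold higher number from compound 1 to compound 3 (1.30 log units; beyond the scatter) is the only measurement of this change, and the difference in the surroundings adds uncertainty. Compound 4 is therefore estimated at 2000 nM, with a likely range from 600 nM to 7000 nM.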

Compound 4, half-maximal inhibitory concentration: 18 nM
The estimate for compound 4 lay 110-fold (2.05 log units) above the measured number; the whole stated range lies above it.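

In this assay, replacing thiophen-3-yl with 2-hydroxyphenyl on the six-membered aromatic ring with 1 nitrogen gave a 5.6-fold lower number from compound 2 to compound 4 (0.74 log units; beyond the scatter), so a change that weakened inhibition on the core of compound 1 strengthened it on the core of compound 2. The effect of this change did not carry from one core to the other, not even in its direction: the same change on two cores in this assay, a 20-fold higher number (1.30 log units; beyond the scatter) from compound 1 to compound 3 and a 5.6-fold lower number (0.74 log units; beyond the scatter) from compound 2 to compound 4, 110-fold (2.05 log units) apart, beyond the scatter of two such steps

The outcome of this change therefore depends on the core that carries it, but a single pair of steps does not show why, nor whether another group would reverse in the same way. The compounds shown leave open whether a methoxy group or an amine in place of the hydroxyl on the phenyl ring would also differ between the two cores. They also leave open whether the reversal seen in this assay would appear in any other test.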